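Swapping a pyridine for a chlorophenyl on the pyridine core

A few compounds are considered here, and "the series" means these few. Any claim that something is new, unique, unknown or untested is made for them only; others in the source may bear on it.

Measured so far:
- compound 1 `Cc1ccccc1-c1cc(-c2ccc(Cl)o2)cc(-c2ccsc2)n1`: 6.7%
- compound 2 `Clc1ccc(-c2cc(-c3ccc(Cl)o3)cc(-c3ccsc3)n2)cc1`: 29.8%
- compound 3 `Clc1ccc(-c2cc(-c3cccnc3)nc(-c3ccsc3)c2)o1`: 0%

All three were tested in an assay on isolated protein for inhibition of DNA topoisomerase 1 (Homo sapiens), tested at 100 uM; a lower number here means a weaker effect, a higher number a stronger effect of the compound at the concentration tested. Going by the values given here, compound 3 gives the lowest of the three numbers, but the step of a number 6.7 percentage points lower from compound 1 to compound 3 (within the scatter) is within the scatter, so compound 3 and compound 1 cannot be told apart; only the step of a number 29.8 percentage points lower from compound 2 to compound 3 (beyond the scatter) is beyond it, and it is modest.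

Compound 4 `Clc1cccc(-c2cc(-c3ccc(Cl)o3)cc(-c3ccsc3)n2)c1` differs from compound 3 in one place: 3-chlorophenyl in place of pyridin-3-yl on an aromatic carbon. The step most closely related runs the other way, a number 29.8 percentage points lower from compound 2 to compound 3 (beyond the scatter), and it is modest. The step of a number 23.1 percentage points higher from compound 1 to compound 2 (beyond the scatter) shows that a chlorophenyl group on the same carbon can give the higher number among these compounds. Among the compounds with values here, compound 4 carries a 3-chlorophenyl rather than a 4-chlorophenyl, and no measured pair covers that difference. A modest rise is therefore expected, a number 20 percentage points higher from compound 3 to compound 4 (beyond the scatter), with wide uncertainty. Compound 4 is estimated at 20%, between 3% and 40%.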

Compound 4, a percentage reported as inhibition, at one concentration (the size of the read-out at that concentration, not a potency): 0%
For compound 4 the middle estimate is 20 percentage points above the measured one, outside the stated range (below it).
By their numbers in this assay, from the lowest: compounds 3, 4 and 1 (each within the scatter of the next); then compound 2.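

Where the chlorine sits on the phenyl ring matters: the step of a number 29.8 percentage points lower from compound 2 to compound 4 (beyond the scatter) shows that a chlorophenyl group on this carbon next to the ring nitrogen does not by itself give the higher number in this assay. The steps of no change at the digits printed from compound 3 to compound 4 (within the scatter) and a number 6.7 percentage points lower from compound 1 to compound 4 (within the scatter) are both within the scatter, so 3-chlorophenyl, pyridin-3-yl and 2-methylphenyl cannot be told apart here, and only the 4-chlorophenyl of compound 2 stands apart. Nothing available explains this difference between the two chlorophenyl groups.

Going by these compounds, it remains open whether the chlorine itself is needed in that ring position, or whether a 4-methylphenyl, 4-methoxyphenyl or 4-aminophenyl group would serve as well. The compounds shown also say nothing about a 2-chlorophenyl group or a carboxylic acid on this carbon.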